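Replacing the Cyanobenzyl Group: Expected Tolerance of Compound 4

A few compounds are considered here, and "the series" means these few. Any claim that something is new, unique, unknown or untested is made for them only; others in the source may bear on it.

Compound 1, `Cc1cc(C)c(Oc2cc(Nc3ccc(C#N)cc3)ncc2C(=O)NCc2cn(Cc3cccc([N+](=O)[O-])c3)nn2)c(C)c1`, in an ADME assay on MT4 cells (Homo sapiens) for cytotoxicity, read by MTT assay, with a stated time of 5 days (a lower number here means that less compound is tolerated, a higher number that more compound is tolerated), gives >= 156000 nM, which is a limit of the assay.
Compound 2, `Cc1cc(C)c(Oc2cc(Nc3ccc(C#N)cc3)ncc2C(=O)NCc2cn(Cc3ccccc3C#N)nn2)c(C)c1`, gives > 219000 nM, also a limit.
Compound 3, `Cc1cc(C)c(Oc2cc(Nc3ccc(C#N)cc3)ncc2C(=O)NCc2cn(CC(=O)N3CCOCC3)nn2)c(C)c1`, gives 181000 nM.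

Compound 2 stands only at a limit; of the three values shown, one further value is a limit, as recorded in the limit of > 219000 nM in this assay, at which 1 of the 3 values shown sits, and (the limit of >= 156000 nM in this assay, at which 1 of the 3 values shown sits). The step that the two limits leave unreadable from compound 1 to compound 2 is therefore unreadable. The step of an at least 1.2-fold lower number from compound 2 to compound 3 (0.08 log units; that floor lies within the scatter) is the only readable one that starts from compound 2, and its floor lies within the scatter.

Compound 4, `COC(=O)Cn1cc(CNC(=O)c2cnc(Nc3ccc(C#N)cc3)cc2Oc2c(C)cc(C)cc2C)nn1`, is not yet measured. It differs from compound 2 as follows: methoxycarbonyl in place of 2-cyanophenyl on a saturated chain carbon bound to an aromatic nitrogen. Within the data shown here, this change, like the one from compound 2 to compound 3, removes the aromatic ring from the saturated chain carbon bound to an aromatic nitrogen, and that step was small. No step beyond the scatter is expected in this assay.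

Compound 4 is therefore expected to give about 200000 nM, within 120000 nM to 320000 nM, a step of an at least 1.0-fold lower number from compound 2 to compound 4 (0.03 log units; that floor lies within the scatter) that is expected to stay within the scatter, with a good chance that only a limit is reported.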

Compound 4, half-maximal cytotoxic concentration: 13800 nM
The estimate for compound 4 lay 14-fold (1.16 log units) above the measured number; measured number below the stated range.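

In this assay, among these compounds, the place on a saturated chain carbon bound to an aromatic nitrogen proves sensitive: the one readable earlier step there had a floor within the scatter, yet a 13-fold lower number from compound 3 to compound 4 (1.12 log units; beyond the scatter) follows from methoxy in place of morpholin-4-yl on a carbonyl carbon. Loss of the aromatic ring alone does not account for compound 4, as compound 3 has no aromatic ring at this place either. The steps of an at least 15-fold lower number from compound 2 to compound 4 (1.20 log units; beyond the scatter) and an at least 11-fold lower number from compound 1 to compound 4 (1.05 log units; beyond the scatter) are floors set by limits of the assay, and the steps from compound 1 to compound 2 and to compound 3 cannot be read.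

Whether the lower number is particular to methoxycarbonyl stays open, as neither a carboxylic acid nor ethoxycarbonyl stands at this place among the compounds shown. Nothing measured here explains the step.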